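This account rests on a few compounds, and the source may have more. Where it says the series, first, only, none or still open, it means among the compounds named here.

Working notes on the chloropurine series

Three compounds have numbers in a functional assay on MCF7 cells (Homo sapiens) for cytotoxicity, read by sulforhodamine B assay, with a stated time of 48 h; on this read-out higher numbers stand for weaker inhibition of growth and lower numbers for stronger inhibition of growth. Compound 1 `ClCc1ccc(Cn2cnc3c(Cl)ncnc32)cc1` gives 410 nM in this assay. Compound 2 `ClCc1ccc(Cn2cnc3nc(Cl)nc(Cl)c32)cc1`, which carries two chloro groups on its core, gives 4160 nM. Compound 3 `ClCc1ccccc1Cn1cnc2ncnc(Cl)c21`, with the chloromethylbenzyl group attached through its ortho position, gives 3630 nM. On these three numbers compound 2 stands highest, that is, weakest at growth inhibition; compound 3 sits next to it, within the scatter, while compound 1 lies well beyond the scatter at the lower end.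

Compound 4 `ClCc1ccc(Cn2cnc3ncnc(Cl)c32)cc1` has not been measured. It differs from compound 2 in one place: hydrogen in place of chloro on an aromatic carbon, so the core of compound 4 keeps a single chloro group, as in compound 1 and compound 3, while the para-substituted benzyl arm of compound 2 is retained. Going by the values given here, no measured pair shows this exact change, so the size of the step is open. Among the compounds with values here, the only monochloro compounds measured, compound 1 at 410 nM and compound 3 at 3630 nM, both lie below compound 2, which suggests the step of a 2.8-fold lower number from compound 2 to compound 4 (0.44 log units; beyond the scatter) is expected to run toward lower numbers, likely beyond the scatter but with wide uncertainty. Compound 4 is therefore estimated at 1500 nM, with a range of 400 nM to 6000 nM.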

Compound 4, concentration for 50% growth inhibition: 1340 nM
Beside the measured number, compound 4's estimate is 1.1-fold (0.05 log units) above it; the range from low to high includes it.
By their numbers in this assay, from the lowest: compound 1; then compound 4; then compounds 3 and 2 (each within the scatter of the next).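

Hydrogen in place of chloro on an aromatic carbon between two ring nitrogen atoms gives a 3.1-fold lower number from compound 2 to compound 4 (0.49 log units; beyond the scatter) in this assay, the first direct reading of this change in the series. The earlier compounds shown here could only hint at the effect of this chloro group, since no two of them formed a matched pair for it; this pair isolates the change with the para-substituted benzyl arm held constant. In this pair, the chloro group at this position is not needed for growth inhibition, as the compound with hydrogen there gives the lower number, and nothing available explains the size or direction of the step.

Going by these compounds, the position is covered only by chloro and hydrogen in a single pair, so it remains open how an amine, a methoxy group or a fluoro group there would compare with either. On these data alone, it is also open whether the same step would appear with the other arrangements of the monochloro compounds, such as the ortho-attached arm of compound 3 or the different attachment to the core in compound 1.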